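The source may report more compounds than this note shows. Statements on the series, on what has been measured and on what is new or still open speak of the compounds shown alone.

Compound 2 `CC(=O)Oc1ccc(/C=C/C(=O)OCCSc2nc(-c3ccc(S(C)(=O)=O)cc3)n(-c3ccc(F)cc3)n2)cc1OC(C)=O` gives 11800 nM in a functional assay on A549 cells (Homo sapiens) for antiproliferative activity, read by MTT assay, with a stated time of 72 h (on this read-out lower numbers stand for stronger inhibition and higher numbers for weaker inhibition), and stands second highest among the three numbers measured. Its nearest neighbour is compound 3 `CC(=O)Oc1ccc(/C=C/C(=O)OCCSc2nc(-c3ccc(S(C)(=O)=O)cc3)n(-c3ccc(C(F)(F)F)cc3)n2)cc1OC(C)=O`, which gives 10200 nM in this assay; the furthest is compound 1 `CSc1nc(-c2ccc(S(N)(=O)=O)cc2)n(-c2ccc(Cl)cc2)n1`, which gives 29500 nM in this assay. Compound 4 `CC(=O)Oc1ccc(/C=C/C(=O)OCCSc2nc(-c3ccc(S(N)(=O)=O)cc3)n(-c3ccc(F)cc3)n2)cc1OC(C)=O` is not yet measured. It differs from compound 2 in one place: amino in place of methyl on a sulfonyl sulfur whose other neighbour is an aromatic carbon. Within the data shown here, no measured pair differs in this place alone. Among the measured compounds shown here, the one measured step, a 1.2-fold lower number from compound 2 to compound 3 (0.06 log units; within the scatter), concerns the aromatic substituent and not the sulfonyl group, and so says little here. Compound 1 carries a sulfamoyl group but also differs from compound 2 elsewhere, so its higher number cannot be assigned to that group. With nothing that bears directly on the change, no step beyond the scatter is expected from compound 2 to compound 4, a 1.2-fold higher number from compound 2 to compound 4 (0.07 log units; within the scatter). Compound 4 is therefore expected to give about 14000 nM in this assay, within a range of 6000 nM to 35000 nM.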

Compound 4, half-maximal inhibitory concentration: 12000 nM
Compound 4: middle estimate off by 1.2-fold (0.07 log units), on the high side; low and high end bracket the measured number.
By their numbers in this assay, from the lowest: compounds 3, 2 and 4 (each within the scatter of the next); then compound 1.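

In this assay, the change gives a 1.0-fold higher number from compound 2 to compound 4 (0.01 log units; within the scatter) and so provides the first pair among the compounds shown that isolates this position; compound 1 also carries a sulfamoyl group, but it differs from compound 2 elsewhere as well. With the rest of the structure held as in compound 2, methylsulfonyl and sulfamoyl cannot be told apart on this read-out, and the one hydrogen-bond donor that enters with the amino group comes with no step beyond the scatter. No evidence is available to explain this result.

On these data alone, whether a methylamino or dimethylamino group on the same sulfonyl sulfur, or a carboxylic acid in place of the whole sulfonyl group, would shift the number remains open. As far as these compounds go, it is also open whether the same change would stay within the scatter alongside the trifluoromethyl group of compound 3.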